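Swapping the pyrazole on the amide nitrogen of compound 1

A few compounds are considered here, and "the series" means these few. Any claim that something is new, unique, unknown or untested is made for them only; others in the source may bear on it.

Measured so far:
compound 1 `Cc1ccc(OCC(=O)N(Cc2cccs2)c2ccn(C)n2)cc1`: 855 nM
compound 2 `CCN(Cc1cccs1)C(=O)COc1ccc(C(F)(F)F)cc1`: 236 nM

Both compounds were tested in an assay on HEK293 cells for agonist activity at transient receptor potential cation channel subfamily M member 8 (Homo sapiens), read by fluorescence and calcium flux, with a stated time of 15 min; a higher number here means that more compound is needed for the effect, a lower number that less compound is needed. Among the two numbers, compound 1 has the highest, and the only other value, that of compound 2 at 236 nM, lies beyond the scatter below it, so compound 1 needs more compound for the same effect than compound 2.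

Compound 3 `Cc1ccc(OCC(=O)N(Cc2cccs2)c2c(C)n[nH]c2C)cc1` is not yet measured. It differs from compound 1 in one place: 3,5-dimethyl-1H-pyrazol-4-yl in place of 1-methyl-1H-pyrazol-3-yl on an amide-type nitrogen. The rest of the molecule, the shared core with its thiophene-bearing side chain and the methylphenoxy acetamide, is unchanged.

Among the compounds with values here, no pair of measured compounds differs in only this kind of place, so there is no measured step to lean on. The expectation is that the step of a 1.2-fold higher number from compound 1 to compound 3 (0.07 log units; within the scatter) will be small, with no clear direction beyond the scatter. Compound 3 is therefore estimated to give 1000 nM in this assay, with a range from 300 nM to 3500 nM.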

Compound 3, half-maximal effective concentration: 0.3 nM
Estimate against measurement, compound 3: 3300-fold (3.52 log units) above; measured number below the stated range.
By their numbers in this assay, from the lowest: compound 3; then compound 2; then compound 1.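

In this assay, within the data shown here, the single change at this place gives a 2900-fold lower number from compound 1 to compound 3 (3.45 log units; beyond the scatter), a large step for a swap that adds only one heavy atom and keeps a five-membered aromatic ring with two hetero atoms. The group on the amide-type nitrogen can therefore decide almost entirely how much compound is needed, even with the rest of the molecule unchanged, which the two earlier compounds could not show because they differ in more than one place. Several things change together in this swap, since 3,5-dimethyl-1H-pyrazol-4-yl differs from 1-methyl-1H-pyrazol-3-yl in its point of attachment and its methyl groups, and it carries a hydrogen-bond donor where the group it replaces has none, and nothing measured here explains the size of the step.

The compounds shown leave open which of these differences matters, and a single step cannot separate them. An unsubstituted pyrazole, a pyrazole with a third methyl group in place of the ring hydrogen, or a phenyl ring on the same nitrogen would each be a further single change at this place, and none of these groups is among the compounds shown.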